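Swapping Carboxy for Hydroxymethyl: an Expected Gain in Inhibition

The compounds below may be only part of what the source reports. "The series", "measured", "known", "first", "only" and "open" are said of these compounds alone.

Measured in a functional assay on Rec1 cells (Homo sapiens) for inhibition, read by luminescence and CellTiter-Glo, with a stated time of 72 h; a lower number here means a stronger inhibitor, a higher number a weaker inhibitor:
Compound 1 `O=C(CCl)Nc1cccc(Cn2nc(-c3ccc(Oc4ccccc4)cc3)cc2CO)c1` gives 400 nM.
Compound 2 `C=CC(=O)Nc1cccc(Cn2nc(-c3ccc(Oc4ccccc4)cc3)cc2CO)c1` gives 1300 nM.
Compound 3 `C/C=C/C(=O)Nc1cccc(Cn2nc(-c3ccc(Oc4ccccc4)cc3)cc2C(=O)O)c1` gives 26000 nM.

Compound 3 gives the highest number of the three, beyond the scatter against both compound 2 and compound 1, so it is the weakest inhibitor here. Compound 4 `C/C=C/C(=O)Nc1cccc(Cn2nc(-c3ccc(Oc4ccccc4)cc3)cc2CO)c1` differs from it by hydroxymethyl in place of carboxy on an aromatic carbon. Among the compounds with values here, the only measured step, a 3.3-fold higher number from compound 1 to compound 2 (0.51 log units; beyond the scatter), alters the amide group instead, so no step isolates this change. Still, compound 1 and compound 2, which carry the hydroxymethyl, both give far lower numbers than compound 3. A marked fall in this assay is therefore expected, an 8.7-fold lower number from compound 3 to compound 4 (0.94 log units; beyond the scatter). Compound 4 is estimated at 3000 nM, within 800 nM to 12000 nM.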

Compound 4, half-maximal inhibitory concentration: 3400 nM
Compound 4: middle estimate off by 1.1-fold (0.05 log units), on the low side; measured number inside the range.
By their numbers in this assay, from the lowest: compound 1; then compound 2; then compound 4; then compound 3.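

In this assay, with the amide end held constant, hydroxymethyl in place of carboxy gives a 7.6-fold lower number from compound 3 to compound 4 (0.88 log units; beyond the scatter), which shows directly that this position on the five-membered ring affects the result. With hydroxymethyl held constant, the amide end matters too: prop-1-en-1-yl in place of vinyl gives a 2.6-fold higher number from compound 2 to compound 4 (0.42 log units; beyond the scatter), and prop-1-en-1-yl in place of chloromethyl gives an 8.5-fold higher number from compound 1 to compound 4 (0.93 log units; beyond the scatter).

From the compounds shown here alone, whether an aminomethyl group, a methyl ester or a longer hydroxyalkyl chain at this position would give a lower or higher number remains open. Nothing available here explains why these changes shift the number.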